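Back from an Open Chain to an Aromatic Ring

The source may report more compounds than this note shows. Statements on the series, on what has been measured and on what is new or still open speak of the compounds shown alone.

In an assay on isolated protein with Bile acid receptor (Homo sapiens) as the target (a lower number here means that less compound is needed, a higher number that more compound is needed for the effect), compound 3 `CCOC/C=C/c1ccc(CN(C(=O)C2CCCCC2)c2cccc(/C=C/C(=O)OC)c2)cc1` gives 198000 nM, the highest number among the three measured compounds. Compound 1 `COC(=O)/C=C/c1cccc(N(Cc2ccc(-c3ccc(OC)cc3)cc2)C(=O)C2CCCCC2)c1` gives 89 nM and compound 2 `COC(=O)/C=C/c1cccc(N(Cc2ccc(-c3cccc(Cl)c3)cc2)C(=O)C2CCCCC2)c1` gives 94 nM; the step of a 1.1-fold higher number from compound 1 to compound 2 (0.02 log units; within the scatter) lies within the scatter. Compound 4 `COC(=O)/C=C/c1cccc(N(Cc2ccc(-c3cccc(OC(F)(F)F)c3)cc2)C(=O)C2CCCCC2)c1` carries the change (3-(trifluoromethoxy)phenyl in place of 3-ethoxyprop-1-en-1-yl on an aromatic carbon). Going by the values given here, two measured steps bear on this, and both were large: a 2200-fold higher number from compound 1 to compound 3 (3.35 log units; beyond the scatter) and a 2100-fold higher number from compound 2 to compound 3 (3.32 log units; beyond the scatter). Because those steps a 2200-fold higher number from compound 1 to compound 3 (3.35 log units; beyond the scatter) and a 2100-fold higher number from compound 2 to compound 3 (3.32 log units; beyond the scatter) ran against an aromatic group being replaced by a chain, and compound 4 brings an aromatic group back, a large decrease is expected for a 1700-fold lower number from compound 3 to compound 4 (3.22 log units; beyond the scatter). Compound 4 is accordingly estimated at 120 nM, with a range from 30 nM to 500 nM.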

Compound 4, half-maximal effective concentration: 420 nM
Estimate against measurement, compound 4: 3.5-fold (0.54 log units) below; measured number inside the range.
By their numbers in this assay, from the lowest: compounds 1 and 2 (each within the scatter of the next); then compound 4; then compound 3.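

Putting an aromatic ring back at this position undoes most of the loss seen with the open chain, with a 470-fold lower number from compound 3 to compound 4 (2.67 log units; beyond the scatter). The ring alone does not fix the number, however: a 4.5-fold higher number from compound 2 to compound 4 (0.65 log units; beyond the scatter) and a 4.7-fold higher number from compound 1 to compound 4 (0.67 log units; beyond the scatter), so in this assay the group carried on that ring can matter, which the first two compounds did not show. Nothing available here accounts for these differences.

The compounds shown leave open whether an amine or a carboxylic acid on that aromatic ring would match compound 1 or compound 4. They also leave open whether a piperidine ring in the same place would serve as well as an aromatic one.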